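Removing the N-methyl and moving the furan linkage: compound 4

This account rests on a few compounds, and the source may have more. Where it says the series, first, only, none or still open, it means among the compounds named here.

Measured so far:
- Compound 1, `CN(Cc1ccco1)C1CCN(CCCc2c[nH]c3ccc(-n4cnnc4)cc23)CC1`: 89 nM
- Compound 2, `CNS(=O)(=O)Cc1ccc2[nH]cc(CCCN3CCC(N[C@H](C)c4ccccc4)CC3)c2c1`: 260 nM
- Compound 3, `CC(=O)Nc1ccc(CNCC2CCN(CCCc3c[nH]c4ccc(-n5cnnc5)cc34)CC2)cc1`: 8.9 nM

All three compounds were tested in an assay on CHO cells for displacement of a labelled ligand from 5-hydroxytryptamine receptor 1B (Homo sapiens); a lower number here means a stronger inhibitor, a higher number a weaker inhibitor. Compound 1 gives 89 nM and stands second highest of the three numbers. Its nearest neighbour is compound 2, whose value is higher by a gap that lies beyond the usual scatter. Furthest from it is compound 3, whose value is lower by a gap that also lies beyond the scatter, so compound 3 is the strongest inhibitor of the three measured.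

The next compound, compound 4, `c1cc(CNC2CCN(CCCc3c[nH]c4ccc(-n5cnnc5)cc34)CC2)co1`, is built from compound 1 by one change on the saturated ring carbon of the shared core: ((furan-3-yl)methyl)amino in place of ((furan-2-yl)methyl)(methyl)amino on a saturated ring carbon. The amine that carried a methyl and a furan-2-ylmethyl group is replaced by an amine with a single hydrogen-bond donor bearing a furan-3-ylmethyl group. No pair of measured compounds differs in exactly this way, so the step has to be guessed from the numbers shown. Since the secondary-amine compound 3 gives 8.9 nM while compound 1 gives 89 nM, a modest move toward stronger binding is expected, and the step of a 2.0-fold lower number from compound 1 to compound 4 (0.30 log units; within the scatter) is estimated to lie just beyond the scatter. Compound 4 is therefore expected to give about 45 nM, within a range from 15 nM to 140 nM.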

Compound 4, half-maximal inhibitory concentration: 78 nM
Compound 4: the middle estimate sits 1.7-fold (0.24 log units) below what was measured; the range from low to high includes it.
By their numbers in this assay, from the lowest: compound 3; then compounds 4 and 1 (each within the scatter of the next); then compound 2.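

In this assay, among the compounds shown here, the first pair of measured compounds that differ in one place gives a direct reading of the amine on the saturated ring carbon, and the step is a 1.1-fold lower number from compound 1 to compound 4 (0.06 log units; within the scatter). Two things change together in this step: the methyl on the amine is gone, leaving a hydrogen-bond donor where there was none, and the furan ring is attached through its 3-position instead of its 2-position, yet the two compounds cannot be told apart in this read-out, so the combined change leaves binding where it was. Nothing measured here explains this result, and the pair cannot show whether each change has little effect alone or whether the two offset each other.

Going by these compounds, what stays open is how much each change contributes, which a ((furan-2-yl)methyl)amino group on the same carbon would separate, since it differs from each of the two compounds in only one respect. Also open, on these data alone, is how far this position tolerates other groups, such as a thiophene ring in place of the furan or a longer chain between the amine and the ring.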